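Neopentyl to tert-butyl on two related cores

A few compounds are considered here, and "the series" means these few. Any claim that something is new, unique, unknown or untested is made for them only; others in the source may bear on it.

Measured so far:
- compound 1 `CC(C)(C)C[C@@H](O)C(=O)N1CC[C@@H]2C[C@@]21C(=O)NCc1cc(Cl)ccc1-n1cnnn1`: 620 nM
- compound 2 `CC(C)(C)[C@@H](O)C(=O)N1[C@H](C(=O)NCc2cc(Cl)ccc2-n2cnnn2)C[C@@H]2C[C@@H]21`: 1500 nM
- compound 3 `CC(C)(C)C[C@@H](O)C(=O)N1[C@H](C(=O)NCc2cc(Cl)ccc2-n2cnnn2)C[C@@H]2C[C@@H]21`: 570 nM

All three were run in a functional assay on a cell-free system (plasma, Homo sapiens), with a stated time of 3 min; on this read-out higher numbers stand for weaker inhibition and lower numbers for stronger inhibition. Compound 1 and compound 3 are built from the same atoms joined differently; the difference between the two cores is not broken down here. Their values lie within the scatter of each other. Compound 3 and compound 2 differ by one change, (tert-butyl in place of neopentyl on a saturated chain carbon bound to a carbonyl carbon and an oxygen on a saturated carbon), and that change gave a 2.6-fold higher number from compound 3 to compound 2 (0.42 log units; beyond the scatter).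

Compound 4 `CC(C)(C)[C@@H](O)C(=O)N1CC[C@@H]2C[C@@]21C(=O)NCc1cc(Cl)ccc1-n1cnnn1` is not yet measured. It stands to compound 1 as compound 2 stands to compound 3: the change is tert-butyl in place of neopentyl on a saturated chain carbon bound to a carbonyl carbon and an oxygen on a saturated carbon, the same change at the same place. If it carries over, the expected step is a 2.4-fold higher number from compound 1 to compound 4 (0.38 log units; beyond the scatter), resting on the step from compound 3 to compound 2. For the measured compounds named here, compound 4 is therefore estimated at 1500 nM, expected between 800 nM and 3000 nM, since only one prior instance supports the transfer.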

Compound 4, half-maximal inhibitory concentration: 1500 nM
For compound 4 middle estimate and measured number coincide at the digits printed; the measured number falls inside the stated range.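

In this assay, tert-butyl in place of neopentyl gives a 2.4-fold higher number from compound 1 to compound 4 (0.38 log units; beyond the scatter), so the change carries over from one core to the other with its size intact. The two steps agree: the same change on two cores in this assay, a 2.6-fold higher number (0.42 log units; beyond the scatter) from compound 3 to compound 2 and a 2.4-fold higher number (0.38 log units; beyond the scatter) from compound 1 to compound 4, 1.1-fold (0.04 log units) apart, within the scatter of two such steps. This supports transfer of this one change between these two cores in this one read-out; it does not show that the step would hold on any further core, nor does it explain why the number rises.

The compounds shown leave open how other groups behave on the saturated chain carbon bound to a carbonyl carbon and an oxygen, for instance isopropyl, cyclohexyl or a longer chain. As far as these compounds go, whether such groups would also give matching steps on both cores remains open.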